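The source may report more compounds than this note shows. Statements on the series, on what has been measured and on what is new or still open speak of the compounds shown alone.

In a functional assay on PANC-1 cells (Homo sapiens) for inhibition, read by MTT assay, with a stated time of 24 h, tested at 10 uM (on this read-out lower numbers stand for less inhibition and higher numbers for more inhibition at the one concentration tested (going by the name of the read-out)), compound 3 `CC(C)=CCC/C(C)=C/CC1Cc2c(OCCCNC(=O)c3ccc([N+](=O)[O-])cc3)cc(=O)n(CCCO)c2CC1(C)C` gives 6.5%, which is the second highest of the three numbers recorded. Its nearest neighbour is compound 1 `CC(C)=CCC1Cc2c(OCCCOc3ccc(Cl)cc3)cc(=O)n(CCCO)c2CC1(C)C`, which in this assay gives 0%, a number within the scatter of compound 3. Furthest from it is compound 2 `CC(C)=CCC/C(C)=C/CC1Cc2c(OCC=C(C)C)cc(=O)n(CCCO)c2CC1(C)C`, which in this assay gives 15.9%, also within the scatter of compound 3, so the three measured compounds cannot be set apart from one another on these numbers.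

Compound 4 `CC(C)=CCC/C(C)=C/CC1Cc2c(OCCCOc3ccc(Cl)cc3)cc(=O)n(CCCO)c2CC1(C)C` has not been measured. It differs from compound 3 by 4-chlorophenoxy in place of ((4-nitrophenyl)carbonyl)amino on a saturated chain carbon, three bonds along the chain from an oxygen on an aromatic ring. Compound 1 carries the same 4-chlorophenoxy group at the end of its chain, though it differs from compound 4 elsewhere in the core, and its low reading in this assay gives no sign that this group raises inhibition. Among the compounds with values here, since no measured pair isolates this change, the step from compound 3 to compound 4 is expected to be small, a number 1.5 percentage points lower from compound 3 to compound 4 (within the scatter), with no direction beyond the scatter. Compound 4 is estimated to give 5% in this assay, within the range 0% to 18%.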

Compound 4, a percentage reported as inhibition, at one concentration (the size of the read-out at that concentration, not a potency): 0%
Compound 4: middle estimate off by 5 percentage points, on the high side; low and high end bracket the measured number.
By their numbers in this assay, from the lowest: compounds 1, 4, 3 and 2 (each within the scatter of the next, the first and the last beyond it).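

In this assay the exchange of ((4-nitrophenyl)carbonyl)amino for 4-chlorophenoxy on this chain gives a number 6.5 percentage points lower from compound 3 to compound 4 (within the scatter) and so does not set the two groups apart. Within the data shown here, with 2-(4-chlorophenoxy)ethyl in place of 2-methylprop-1-en-1-yl on a saturated chain carbon bound to an oxygen on an aromatic ring, the series shows a number 15.9 percentage points lower from compound 2 to compound 4 (beyond the scatter) as its only step beyond the scatter, and a modest one. The change elsewhere, 3-methylbut-2-en-1-yl in place of hydrogen on a saturated chain carbon bound to a double-bonded chain carbon, gives no change at the digits printed from compound 1 to compound 4 (within the scatter) and leaves the reading where it stood.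

No measurement shown here accounts for any of these steps. Going by these compounds, whether an amine or a carboxylic acid at the end of this chain would change the reading remains open.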